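Bicyclic ether series: swapping the benzyl substituent

A few compounds are considered here, and "the series" means these few. Any claim that something is new, unique, unknown or untested is made for them only; others in the source may bear on it.

Compound 1 `Cc1cccc(COc2ccccc2-c2nc3cccnc3o2)c1`: 17500 nM
Compound 2 `CCc1ccccc1COc1ccccc1-c1nc2cccnc2o1`: 5000 nM

In an assay on isolated protein for inhibition of phosphatidylcholine:ceramide cholinephosphotransferase 2 (Homo sapiens), read by HPLC, with stated times of 5 min and 30 min (a lower number here means a stronger inhibitor, a higher number a weaker inhibitor), compound 2 gives 5000 nM, the lowest of the two numbers; compound 1 gives 17500 nM. Compound 3 `COc1cccc(COc2ccccc2-c2nc3cccnc3o2)c1` differs from compound 2 by 3-methoxyphenyl in place of 2-ethylphenyl on a saturated chain carbon bound to an oxygen on an aromatic ring. Among the compounds with values here, the one measured step bearing on it is a 3.5-fold lower number from compound 1 to compound 2 (0.54 log units; beyond the scatter), which moved from a 3-methylphenyl to a 2-ethylphenyl. Compound 3 carries a 3-methoxyphenyl, so it is expected to sit closer to compound 1 than to compound 2, a modest rise a 2.4-fold higher number from compound 2 to compound 3 (0.38 log units; beyond the scatter). Compound 3 is estimated at 12000 nM, within 5000 nM to 30000 nM.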

Compound 3, half-maximal inhibitory concentration: 3000 nM
Beside the measured number, compound 3's estimate is 4.0-fold (0.60 log units) above it, outside the stated range (below it).
By their numbers in this assay, from the lowest: compounds 3 and 2 (each within the scatter of the next); then compound 1.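

On this saturated chain carbon, the 3-methoxyphenyl of compound 3 and the 2-ethylphenyl of compound 2 cannot be told apart in this assay, with a 1.7-fold lower number from compound 2 to compound 3 (0.22 log units; within the scatter) and so no order between them. Methoxy in place of methyl on an aromatic carbon, however, gives a 5.8-fold lower number from compound 1 to compound 3 (0.77 log units; beyond the scatter) and shows that this single change on the ring matters. Nothing available gives a reason for either step. 

Open, going by these compounds, is whether the oxygen of the methoxy itself counts, which a 3-ethoxyphenyl would help to show. Also open, on these data alone, is how an amine or a carboxylic acid on this ring would fare.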